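Swapping the Bromophenyl Amide for a Cyanophenyl Amide

The compounds below may be only part of what the source reports. "The series", "measured", "known", "first", "only" and "open" are said of these compounds alone.

Compound 1 `COC(=O)CCCCNc1ncc(C(Oc2ccc3cc(Br)ccc3c2)c2ccc(Cl)cc2)s1` and compound 2 `O=C(Nc1ncc(C(Oc2ccc3cc(Br)ccc3c2)c2ccc(Cl)cc2)s1)c1ccc(Br)cc1` share a core and were both examined in an ADME assay on HepG2 2.2.15 cells (Homo sapiens) for cytotoxicity; on this read-out higher numbers stand for lower toxicity in this test and lower numbers for higher toxicity in this test. Compound 1 was recorded in this assay only as "not toxic" (no number reported). For compound 2, this assay reports only a limit, > 50000 nM, not a single number. Compound 2 thus stands at the limit of > 50000 nM in this assay, at which 1 of the 2 values shown sits. Compound 3 `N#Cc1cccc(C(=O)Nc2ncc(C(Oc3ccc4cc(Br)ccc4c3)c3ccc(Cl)cc3)s2)c1` has not yet been tested in this assay. It differs from compound 2 by 3-cyanophenyl in place of 4-bromophenyl on a carbonyl carbon; cut one bond further out, this reads (4-bromophenyl)carbonyl to (3-cyanophenyl)carbonyl. Among the compounds with values here, no step between measured compounds is available, so the size of this change can only be anticipated. Because compound 2 already sits at the limit of > 50000 nM in this assay, at which 1 of the 2 values shown sits, the reading is not expected to move beyond the scatter. The step that the limit leaves unreadable from compound 2 to compound 3 is therefore expected to be none beyond the scatter. Compound 3 is estimated at 60000 nM, within 20000 nM to 150000 nM, with a limit rather than a number the likelier report.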

Compound 3, half-maximal cytotoxic concentration: > 50000 nM
Compound 3 was reported as a limit; the forecaster's own chance of this, stated with the estimate: 75%; the middle value lies beyond the limit too.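

In this assay compound 3 gives > 50000 nM, a limit and not a number. No step from compound 2 to compound 3 can be read, because both stop at a limit: the limit of > 50000 nM in this assay, at which 2 of the 3 values shown sit.

The compounds shown leave open whether 3-cyanophenyl in place of 4-bromophenyl changes this read-out at all.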